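Tert-butyl in place of bromo: what to expect in cytotoxicity

The compounds below may be only part of what the source reports. "The series", "measured", "known", "first", "only" and "open" are said of these compounds alone.

Measured compounds:
compound 1 `O=C1N(CCCCCCOc2ccc(F)cc2)CCN1c1cccnc1` gives > 25000 nM
compound 2 `O=C1N(CCCCCCOc2ccc(Br)cc2)CCN1c1cccnc1` gives > 25000 nM

In a functional assay on cells (Homo sapiens) for cytotoxicity (on this read-out lower numbers stand for higher toxicity in this test and higher numbers for lower toxicity in this test), compound 1 gives > 25000 nM, which is a limit of the assay rather than a number. Compound 2 gives > 25000 nM, again only a limit of the assay. Going by the values given here, the only measured step, a step that the two limits leave unreadable from compound 1 to compound 2, therefore cannot be read, because the limit of > 25000 nM in this assay, at which 2 of the 2 values shown sit, holds both values and hides whatever difference there may be between them. Compound 2 thus stands at the limit, with nothing to set it apart from compound 1.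

Compound 3 `CC(C)(C)c1ccc(OCCCCCCN2CCN(c3cccnc3)C2=O)cc1` differs from compound 2 by tert-butyl in place of bromo on an aromatic carbon. Among the compounds with values here, no measured step shows what such a change does, since the one step at hand, from fluoro to bromo, left no readable size. The expectation can rest only on the fact that compound 2 and compound 1 both sit at the limit, so compound 3 is expected to sit there too, with a step of none beyond the scatter. Compound 3 is estimated at 30000 nM, in a range from 8000 nM to 100000 nM. The expected step that the limit leaves unreadable from compound 2 to compound 3 is accordingly small.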

Compound 3, half-maximal cytotoxic concentration: > 25000 nM
Compound 3: only a limit was reported; the forecaster's own chance of this, stated with the estimate: 70%; the middle value is on the limit's open side.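

In this assay compound 3 gives > 25000 nM as a limit of the assay, not a number. Going by these compounds alone, no step among compound 1, compound 2 and compound 3 can be read, because all three values rest at the same limit: (the limit of > 25000 nM in this assay, at which 3 of the 3 values shown sit). The compounds shown leave open whether their cytotoxicity differs at all, and by how much.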